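This account rests on a few compounds, and the source may have more. Where it says the series, first, only, none or still open, it means among the compounds named here.

Measured compounds:

compound 1 `COc1ccc(-c2cc(=O)c3c(OC)cc(OC)cc3n2S(=O)(=O)c2ccc(C)c([N+](=O)[O-])c2)cc1` — > 51700 nM
compound 2 `COc1ccc(-c2cc(=O)c3c(OC)cc(OC)cc3n2S(=O)(=O)c2ccc(C)cc2)cc1` — > 44800 nM
compound 3 `COC(=O)c1cc(=O)c2cc(NC(=O)Nc3ccc(C(F)(F)F)cc3[N+](=O)[O-])ccc2[nH]1` — > 51700 nM

All three were tested in an ADME assay on BJ cells (Homo sapiens) for antiproliferative activity, with a stated time of 72 h; a higher number here means that more compound is needed for the effect, a lower number that less compound is needed. In this assay compound 1 gives > 51700 nM, which is a limit of the assay and not a number. Compound 2 gives > 44800 nM in this assay, again a limit and not a number. The change from compound 1 to compound 2 is hydrogen in place of nitro on an aromatic carbon, and the step that the two limits leave unreadable from compound 1 to compound 2 cannot be read because the limit of > 44800 nM in this assay, at which 1 of the 3 values shown sits, and the limit of > 51700 nM in this assay, at which 2 of the 3 values shown sit, are all that is known for the pair.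

Compound 3 has a different core; how the two cores differ is not broken down here. In this assay compound 3 gives > 51700 nM, once more a limit and not a number.

Compound 4 `COC(=O)c1cc(=O)c2cc(NC(=O)Nc3ccc(C(F)(F)F)cc3)ccc2[nH]1` has not yet been measured. It differs from compound 3 by hydrogen in place of nitro on an aromatic carbon. Among the measured compounds shown here, this is the same kind of change as the one from compound 1 to compound 2, though not the same: in compound 1 the nitro sits ortho to a methyl group and meta to a large group, while in compound 3 it sits ortho to a large group and meta to a trifluoromethyl group.

The step from compound 3 to compound 4 is expected to be about a step that the limit leaves unreadable from compound 3 to compound 4, an expectation that rests on compound 3 sitting at the limit of > 51700 nM in this assay, at which 2 of the 3 values shown sit, with no readable number. For compound 4 the estimated value in this assay is 60000 nM, spanning 15000 nM to 250000 nM.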

Compound 4, half-maximal effective concentration: > 12600 nM
Compound 4 was reported as a limit; the forecaster's own chance of this, stated with the estimate: 75%; the middle value is on the limit's open side.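

In this assay compound 4 gives > 12600 nM, which is a limit of the assay and not a number. Among the compounds shown here, compound 3 also stands only at a limit, so the step between compound 3 and compound 4 cannot be read and this result adds no new step. The compounds shown leave open whether hydrogen in place of nitro changes the concentration needed in this assay at all, in either pair.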